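The source may hold more compounds than are shown below. What is called first, only, known or untested is meant among the compounds shown, and "the series" means these compounds.

In an ADME assay on HepG2 cells (Homo sapiens) for cytotoxicity, read by luminescence, CellTiter-Glo and ATP content, with a stated time of 72 h (on this read-out lower numbers stand for an effect already at smaller amounts and higher numbers for an effect only at larger amounts of compound), compound 1 `c1ccc(Oc2ccc3c(NCCCNCc4ccco4)ccnc3c2)cc1` gives 15200 nM, compound 2 `COc1ccc(F)cc1CNCCCNc1ccnc2cc(C3CCCCC3)ccc12` gives 2290 nM, and compound 3 `CCC(CC)c1ccc2c(NCCCNCc3cccc(OC)c3O)ccnc2c1` gives 410 nM. Compound 2 therefore stands second highest of the three numbers: its value lies between the other two, and both gaps are beyond the scatter, the gap to compound 3 being the smaller and the gap to compound 1 the larger.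

Compound 4 `COc1ccc(F)cc1CNCCCNc1ccnc2cc(Cc3ccc(F)cc3Cl)ccc12` has not yet been measured in this assay. It differs from compound 2 in one place: 2-chloro-4-fluorobenzyl in place of cyclohexyl on an aromatic carbon. Going by the values given here, no pair of measured compounds here differs in a single place, so there is no measured step on which to rest a prediction of this change; the three values only show that changes at this position of the shared core can move the read-out by more than the scatter in either direction.

The step from compound 2 to compound 4 is expected to be a 1.5-fold lower number from compound 2 to compound 4 (0.18 log units; within the scatter), a modest shift that may well stay within the scatter. Compound 4 is accordingly estimated at 1500 nM, with a range from 400 nM to 6000 nM.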

Compound 4, half-maximal effective concentration: 2460 nM
For compound 4 the middle estimate is 1.6-fold (0.21 log units) below the measured one, and the stated range covers the measured number.
By their numbers in this assay, from the lowest: compound 3; then compounds 2 and 4 (each within the scatter of the next); then compound 1.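

Going by these compounds alone, replacing cyclohexyl with 2-chloro-4-fluorobenzyl on this aromatic carbon gives a 1.1-fold higher number from compound 2 to compound 4 (0.03 log units; within the scatter) in this assay and provides the first single-place step at this position. The earlier compounds shown here differed in more than one place and could not isolate this position, whereas this pair shows that these two groups, one a non-aromatic carbon ring and the other a halogen-bearing aromatic ring, cannot be told apart on this read-out. Nothing measured here bears on the reason for this result.

As far as these compounds go, whether other groups at this place would behave alike remains open, for example a primary amine, a carboxylic acid or a longer alkyl chain. Compound 1 and compound 3 also differ from compound 2 in more than one place, so the share of this position in their values remains unresolved.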